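Taking the hydroxy group off a weak inhibitor

The source may hold more compounds than are shown below. What is called first, only, known or untested is meant among the compounds shown, and "the series" means these compounds.

In a functional assay on a cell-free system (Platelet, plasma, Oryctolagus cuniculus) for inhibition, with a stated time of 5 min, at 37 degrees C (on this read-out higher numbers stand for weaker inhibition and lower numbers for stronger inhibition), compound 1 (`CCOC(=O)/C=C/c1ccc(OC(=O)c2nc(C)c(C)nc2C)c(O)c1`) gives 77400 nM, while compound 2 (`Cc1nc(C)c(C(=O)Oc2cccc(/C=C/C(=O)O)c2)nc1C`) gives 26400 nM. Compound 1 therefore holds the higher of the two numbers, and so is the weaker inhibitor of this pair, by a gap beyond the usual scatter.

Compound 3 (`CCOC(=O)/C=C/c1ccc(OC(=O)c2nc(C)c(C)nc2C)cc1`) has not yet been measured in this assay. It differs from compound 1 in one place: hydrogen in place of hydroxy on an aromatic carbon. For the measured compounds named here, no measured pair shows this change on its own, so the data give no direct guide to its direction. Only a modest shift is expected, with no clear change beyond the scatter. The expected step, a 1.2-fold lower number from compound 1 to compound 3 (0.08 log units; within the scatter), is therefore small. For compound 3 the estimated value is 65000 nM, with an expected range from 28000 nM to 150000 nM.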

Compound 3, half-maximal inhibitory concentration: 24400 nM
Compound 3: middle estimate off by 2.7-fold (0.43 log units), on the high side; measured number outside the range, below it.
By their numbers in this assay, from the lowest: compounds 3 and 2 (each within the scatter of the next); then compound 1.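

Swapping the hydroxy group for hydrogen brings a 3.2-fold lower number from compound 1 to compound 3 (0.50 log units; beyond the scatter) in this assay. For the compounds shown here, this is the first direct reading of this change, since the earlier pair differed in more than one place. At this aromatic carbon, ortho to a large group, the hydroxy group is therefore not needed for the inhibition seen here, and inhibition is stronger with hydrogen in its place. Nothing measured here explains why the change has this effect.

On these data alone, whether other groups on the same carbon, such as a methoxy group, a fluorine atom or an amine, would give stronger or weaker inhibition remains open. As far as these compounds go, it is also open whether the same swap would produce a similar step in a compound with a longer chain in place of the ethyl end of the 2-(ethoxycarbonyl)ethenyl group.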